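The source may report more compounds than this note shows. Statements on the series, on what has been measured and on what is new or still open speak of the compounds shown alone.

Working notes on the series. The shared core is a hydroxybenzoate ester joined through an ethylene chain to a second aromatic ring, which carries the variation. Compound 1 `COC(=O)c1cc(CCc2ccccc2OC)ccc1O` gives 20000 nM in a functional assay on HaCaT cells (Homo sapiens) for antiproliferative activity, read by sulforhodamine B assay, with a stated time of 3 days; a lower number here means a stronger inhibitor, a higher number a weaker inhibitor; compound 2 `COC(=O)c1cc(CCc2cccc(OC)c2OC)ccc1O` gives 33000 nM and the step of a 1.7-fold higher number from compound 1 to compound 2 (0.22 log units; within the scatter) is within the scatter. Compound 3 `COC(=O)c1cc(CCc2c(OC)cccc2OC)ccc1O` gives 110 nM, the lowest of the three numbers, and the step of a 180-fold lower number from compound 1 to compound 3 (2.26 log units; beyond the scatter) is far beyond the scatter.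

Compound 4 `COC(=O)c1cc(CCc2c(OC)ccc(OC)c2OC)ccc1O` differs from compound 3 by methoxy in place of hydrogen on an aromatic carbon. Among the compounds with values here, the only comparable step, adding a methoxy onto a ring that already holds one, is the step from compound 1 to compound 2, which stayed within the scatter. Compound 4 is therefore expected near compound 3, with the step of a 1.8-fold higher number from compound 3 to compound 4 (0.26 log units; within the scatter) likely within the scatter; the estimate for compound 4 is 200 nM (60 nM to 900 nM).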

Compound 4, half-maximal inhibitory concentration: 3500 nM
For compound 4 the middle estimate is 18-fold (1.24 log units) below the measured one; measured number above the stated range.
By their numbers in this assay, from the lowest: compound 3; then compound 4; then compounds 1 and 2 (each within the scatter of the next).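

Placing a methoxy on the ring of compound 3, ortho to a methoxy group and para to a methoxy group, gives a 32-fold higher number from compound 3 to compound 4 (1.50 log units; beyond the scatter), so this change does not carry over unchanged from one core to another: the same change on two cores in this assay, a 1.7-fold higher number (0.22 log units; within the scatter) from compound 1 to compound 2 and a 32-fold higher number (1.50 log units; beyond the scatter) from compound 3 to compound 4, 19-fold (1.29 log units) apart, beyond the scatter of two such steps

The other methoxy step keeps its direction on a ring already holding two methoxy groups, at a 9.4-fold lower number from compound 2 to compound 4 (0.97 log units; beyond the scatter), but it is much smaller there: the same change on two cores in this assay, a 180-fold lower number (2.26 log units; beyond the scatter) from compound 1 to compound 3 and a 9.4-fold lower number (0.97 log units; beyond the scatter) from compound 2 to compound 4, 19-fold (1.29 log units) apart, beyond the scatter of two such steps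

The compounds shown leave open whether the rise at this place is specific to methoxy or would also hold for a hydroxyl or an amine there.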